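A few compounds are considered here, and "the series" means these few. Any claim that something is new, unique, unknown or untested is made for them only; others in the source may bear on it.

Series in a functional assay on MCF7 cells (Homo sapiens) for antiproliferative activity, with a stated time of 96 h; on this read-out higher numbers stand for weaker inhibition and lower numbers for stronger inhibition:
- Compound 1 `Cc1cc(=O)oc2cc(OCC(=O)c3ccc(F)cc3)ccc12`: > 100000 nM (a limit)
- Compound 2 `COc1cccc(C(=O)COc2ccc3c(C(F)(F)F)cc(=O)oc3c2)c1`: "not active" (no number reported)
- Compound 3 `COc1ccc(C(=O)COc2ccc3c(C(F)(F)F)cc(=O)oc3c2)cc1`: "not active" (no number reported)

Compound 3 has no single number on this read-out and is reported as "not active" (no number reported). Compound 2 is reported in the same way as "not active" (no number reported). Compound 1 gives > 100000 nM, which is a limit and not a number. Among the compounds with values here, no compound therefore has a measured potency to serve as a reference.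

Compound 4 `O=C(COc1ccc2c(C(F)(F)F)cc(=O)oc2c1)c1ccc(F)cc1` has not yet been measured in this assay. The change is fluoro in place of methoxy on an aromatic carbon, para to a large group, or 4-methoxyphenyl to 4-fluorophenyl.

No step beyond the scatter is expected in this assay, and the likeliest report for compound 4 is again no activity or a limit. Compound 1 already carries 4-fluorophenyl and gives > 100000 nM, a limit. If a number is reported, the estimate for compound 4 is 60000 nM, with an expected range of 15000 nM to 100000 nM.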

Compound 4, half-maximal inhibitory concentration: "not active" (no number reported)
Compound 4: no number reported, so the estimate cannot be set against anything.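

Compound 3 and compound 4 are both reported as not active in this assay, without a number, so no step can be read between them. The compounds shown leave open whether 4-methoxyphenyl and 4-fluorophenyl differ at all in potency on this read-out.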